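Dropping a Fluoro Group from a Compound with a Low Number

A few compounds are considered here, and "the series" means these few. Any claim that something is new, unique, unknown or untested is made for them only; others in the source may bear on it.

Compound 1 `CC(C)(C(=O)Nc1ccc(C(=O)Nc2ccc(F)cc2N)cc1)c1ccccc1` is one of two compounds tested in an assay on isolated protein for inhibition of histone deacetylase 4 (Homo sapiens), tested at 1 uM; a higher number here means more inhibition at the concentration tested (going by the name of the read-out), a lower number less inhibition. Compound 1 gives 0%, the lower of the two numbers. Compound 2 `CC(C)[C@@H](C(=O)Nc1ccc(C(=O)Nc2ccccc2N)cc1)c1ccccc1` gives 9%, which lies within the scatter of compound 1, so the two cannot be told apart. Compound 3 `CC(C)(C(=O)Nc1ccc(C(=O)Nc2ccccc2N)cc1)c1ccccc1` differs from compound 1 in one place: hydrogen in place of fluoro on an aromatic carbon. Going by the values given here, no measured pair shows the effect of this change, so the only guide is that both measured compounds sit near zero. Compound 3 is expected to stay there, with a step of a number 3 percentage points higher from compound 1 to compound 3 (within the scatter) that means no change beyond the scatter. The estimate for compound 3 is 3%, between -8% and 15%.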

Compound 3, a percentage reported as inhibition, at one concentration (the size of the read-out at that concentration, not a potency): 6%
The estimate for compound 3 lay 3 percentage points below the measured number, and the stated range covers the measured number.
By their numbers in this assay, from the lowest: compounds 1, 3 and 2 (each within the scatter of the next).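

In this assay, hydrogen in place of fluoro on this aromatic carbon, meta to the amino group, gives a number 6 percentage points higher from compound 1 to compound 3 (within the scatter) and so no change that can be told from the scatter. Going by these compounds alone, this pair is the only direct reading of the change, and it shows that losing the fluoro group does not lift the number clear of the low range. No measurement available here offers an explanation for this result.

Going by these compounds, whether a methoxy group or an amine at this position would raise the number remains open. With both compounds so close to zero, any change that lowers inhibition would be hard to detect.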